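Reversing the enone linker on a pyrazolopyrimidine chalcone

The source may report more compounds than this note shows. Statements on the series, on what has been measured and on what is new or still open speak of the compounds shown alone.

Of the compounds shown here, three sharing one core have been measured in a functional assay on MDA-MB-231 cells (Homo sapiens) for antiproliferative activity, read by MTT assay, with a stated time of 24 h; a lower number here means a stronger inhibitor, a higher number a weaker inhibitor. Compound 1 `COc1ccc(C(=O)/C=C/c2cc(-c3cc(OC)c(OC)c(OC)c3)n3nc(-c4ccccc4)cc3n2)cc1` gives 13200 nM. Compound 2 `COc1ccc(/C=C/C(=O)c2cc(-c3cc(OC)c(OC)c(OC)c3)n3nc(-c4ccccc4)cc3n2)cc1OC` gives 14200 nM. Compound 3 `COc1cc(-c2cc(/C=C/C(=O)c3ccc(C)c(C)c3)nc3cc(-c4ccccc4)nn23)cc(OC)c1OC` gives 13500 nM, which is the second highest of the three numbers, with compound 1 nearest at a gap within the scatter and compound 2 furthest, also within the scatter.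

Compound 4 `COc1ccc(/C=C/C(=O)c2cc(-c3cc(OC)c(OC)c(OC)c3)n3nc(-c4ccccc4)cc3n2)cc1` has not yet been measured in this assay. It differs from compound 3 in one place: (2-(4-methoxyphenyl)ethenyl)carbonyl in place of 2-((3,4-dimethylphenyl)carbonyl)ethenyl on an aromatic carbon. Among the measured compounds shown here, the only step that bears on this is the one between the two measured enone-bearing analogues of the same orientation, a 1.0-fold higher number from compound 1 to compound 3 (0.01 log units; within the scatter), which changed nothing beyond the scatter. Compound 2, whose value sits within the scatter of both, gives no sign of any larger movement among these three. No step beyond the scatter is therefore expected from compound 3 to compound 4, no change at the digits printed from compound 3 to compound 4 (within the scatter). Compound 4 is estimated at 13500 nM, within a range from 6500 nM to 28000 nM.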

Compound 4, half-maximal inhibitory concentration: 16500 nM
Beside the measured number, compound 4's estimate is 1.2-fold (0.09 log units) below it; measured number inside the range.
By their numbers in this assay, from the lowest: compounds 1, 3, 2 and 4 (each within the scatter of the next).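

Reversing the enone linker while keeping the 4-methoxyphenyl group gives a 1.3-fold higher number from compound 1 to compound 4 (0.10 log units; within the scatter) in this assay, so among these compounds the orientation of the linker on this aromatic carbon makes no difference that can be read. The other two comparisons agree: the full exchange of the side chain gives a 1.2-fold higher number from compound 3 to compound 4 (0.09 log units; within the scatter) and hydrogen in place of methoxy gives a 1.2-fold higher number from compound 2 to compound 4 (0.07 log units; within the scatter) on the same scale, which shows that neither change moves the number beyond the scatter. Nothing available offers a reason for this flat result.

On these data alone, all four compounds carry an aryl enone at this position, so it remains open whether an amine, a carboxylic acid or a longer chain on that aryl ring would shift the number. As far as these compounds go, the response to replacing the 3,4,5-trimethoxyphenyl group also remains open.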